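The compounds below may be only part of what the source reports. "The series", "measured", "known", "first", "only" and "open" are said of these compounds alone.

In a functional assay on the whole organism (strain albino) for inhibition, with Rattus norvegicus as the target, read by paw edema, with stated times of 30 min and 3 h, at a dose of 0.28 mmol/kg by the oral route (a lower number here means less inhibition, a higher number more inhibition at the dose given (going by the name of the read-out)), compound 2, whose structure is `C=CCn1c(SCC(=O)Nc2ccc(/C(C)=N/O)cc2)nnc1-c1ccccc1`, gives 73%. Compound 1, with the structure `COc1cc(-c2nnc(SCC(=O)Nc3ccc(/C(C)=N/O)cc3)n2-c2ccccc2)cc(OC)c1OC`, gives 66% in this assay, and the two numbers lie within the scatter of each other, so compound 2 stands alongside compound 1 rather than apart from it. Compound 3, with the structure `C/C(=N\O)c1ccc(NC(=O)CSc2nnc(-c3ccccc3)n2-c2ccccc2)cc1`, has not yet been measured in this assay. Compound 3 differs from compound 2 by phenyl in place of allyl on an aromatic nitrogen. Going by the values given here, no step between measured compounds touches this nitrogen alone, so nothing directly shows what the exchange does. Because compound 1, which carries a phenyl on the same nitrogen, gives 66%, the change is expected to bring no step beyond the scatter, and the expected step of a number 5 percentage points lower from compound 2 to compound 3 (within the scatter) is therefore small. Compound 3 is estimated to give 68% in this assay, within a range from 55% to 80%.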

Compound 3, a percentage reported as inhibition, in the whole organism at one dose (the size of the read-out at that dose, not a potency): 63%
The estimate for compound 3 lay 5 percentage points above the measured number, and the stated range covers the measured number.
By their numbers in this assay, from the lowest: compounds 3, 1 and 2 (each within the scatter of the next).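

In this assay, the exchange on the aromatic nitrogen now has a direct reading: phenyl in place of allyl gives a number 10 percentage points lower from compound 2 to compound 3 (within the scatter), so this nitrogen carries either group without a step beyond the scatter. Going by these compounds alone, the same compound gives the first reading on the aromatic carbon, where phenyl in place of 3,4,5-trimethoxyphenyl gives a number 3 percentage points lower from compound 1 to compound 3 (within the scatter), again without a step beyond the scatter. No measurement at hand bears on why these steps are as they are.

On these data alone, whether a longer chain, an amine or a carboxylic acid on the aromatic nitrogen would give a step beyond the scatter remains open. As far as these compounds go, all these numbers stand at a single dose, so how the compounds compare in potency also remains open.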